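Two Stereoisomers at the Cytotoxicity Limit

The source may report more compounds than this note shows. Statements on the series, on what has been measured and on what is new or still open speak of the compounds shown alone.

Cytotoxicity in the series has so far been read in a functional assay on Vero cells (Chlorocebus sabaeus) for cytotoxicity; on this read-out higher numbers stand for weaker inhibition and lower numbers for stronger inhibition. In this assay compound 1 `Nc1ccn([C@H]2CC(F)(F)[C@H](CO)O2)c(=O)n1` gives > 100000 nM, which is a limit of the assay and not a number. Compound 2 `Nc1nc(=O)n([C@@H]2CC(F)(F)[C@H](CO)O2)cc1F` gives > 100000 nM, which is also a limit. Compound 2 therefore has no exact value, and the one other result is a limit too: the limit of > 100000 nM in this assay, at which 2 of the 2 values shown sit. Within the data shown here, no step between measured compounds is available.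

Compound 3 `Nc1nc(=O)n([C@H]2CC(F)(F)[C@H](CO)O2)cc1F` is the next to be read, and it relates to compound 2 through (the two compounds have the same atoms and bonds and differ only in configuration as drawn: 1 of 2 stereo elements differ; a stereocentre at a saturated ring carbon is drawn S in compound 2 and R in compound 3). A stereocentre at a saturated ring carbon is drawn S in compound 2 and R in compound 3.

In this assay, no change beyond the usual scatter is expected, in either direction, because both results so far sit at the limit of > 100000 nM in this assay, at which 2 of the 2 values shown sit. The expected change is a number no higher from compound 2 to compound 3 (the limit leaves the size open). Compound 3 is most likely to be reported only as a limit as well. As a number, compound 3 is estimated at 100000 nM, within an expected range of 40000 nM to 200000 nM.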

Compound 3, half-maximal inhibitory concentration: > 100000 nM
Compound 3: a limit, no number; the forecaster's own chance of this, stated with the estimate: 90%; the middle value sits exactly at the limit.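

The steps from compound 2 to compound 3 and from compound 1 to compound 3 cannot be read, and compounds 1, 2 and 3 therefore give no comparison: the limit of > 100000 nM in this assay, at which 3 of the 3 values shown sit.

The compounds shown leave open at what concentration, if any, each of them would register a number in this assay.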